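Trifluoromethoxy to cyano: what compound 4 may show

The source may report more compounds than this note shows. Statements on the series, on what has been measured and on what is new or still open speak of the compounds shown alone.

Measured so far in an ADME assay on WI-38 cells (Homo sapiens) for cytotoxicity, read by MTT assay, with a stated time of 72 h; on this read-out lower numbers stand for stronger inhibition and higher numbers for weaker inhibition
compound 1 `O=C(CCc1cccc2c1B(O)OC2)Nc1cccc(-c2cccc(Cl)c2)c1` gives 58000 nM
compound 2 `COc1cc(OC)cc(-c2cccc(NC(=O)CCc3cccc4c3B(O)OC4)c2)c1` gives 1700 nM
compound 3 `O=C(CCc1cccc2c1B(O)OC2)Nc1cccc(-c2cccc(OC(F)(F)F)c2)c1` gives 9800 nM

Compound 3 stands in the middle of these three numbers, below compound 1 and above compound 2. Compound 4 `N#Cc1cccc(-c2cccc(NC(=O)CCc3cccc4c3B(O)OC4)c2)c1` carries cyano in place of trifluoromethoxy on an aromatic carbon. Within the data shown here, two measured steps bear on this change, both starting from compound 1: a modest one (a 5.9-fold lower number from compound 1 to compound 3 (0.77 log units; beyond the scatter)) and a large one (a 34-fold lower number from compound 1 to compound 2 (1.53 log units; beyond the scatter)). Neither involves cyano, so they show that this assay can move with this substituent but give no direction for the new change. No step beyond the scatter is therefore expected (a 1.4-fold higher number from compound 3 to compound 4 (0.15 log units; within the scatter)). Compound 4 is estimated at 14000 nM (expected range 4000 nM to 45000 nM).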

Compound 4, half-maximal inhibitory concentration: 7300 nM
Estimate against measurement, compound 4: 1.9-fold (0.28 log units) above; low and high end bracket the measured number.
By their numbers in this assay, from the lowest: compound 2; then compounds 4 and 3 (each within the scatter of the next); then compound 1.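

In this assay, cyano and trifluoromethoxy cannot be told apart on this aromatic carbon (a 1.3-fold lower number from compound 3 to compound 4 (0.13 log units; within the scatter)), although cyano is the smaller group by heavy atoms. Cyano also stands clearly apart from chloro (a 7.9-fold lower number from compound 1 to compound 4 (0.90 log units; beyond the scatter)), but it does not match the 3,5-dimethoxyphenyl of compound 2 (a 4.3-fold higher number from compound 2 to compound 4 (0.63 log units; beyond the scatter)). No measurement shown explains these differences. On these data alone, whether an amine or a carboxylic acid here would fall with cyano and trifluoromethoxy or nearer 3,5-dimethoxyphenyl remains open. So does whether a single methoxy in place of cyano would give the number of compound 2.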